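Sulfur substituent change in the hydroxycitrate-type series

The source may report more compounds than this note shows. Statements on the series, on what has been measured and on what is new or still open speak of the compounds shown alone.

Among the compounds with values here, compound 1 `CS[C@H](C(=O)O)[C@@](O)(CC(=O)O)C(=O)O` is the stronger of the two measured members. In an assay on isolated protein with ATP-citrate synthase (Rattus norvegicus) as the target (a higher number here means a weaker inhibitor, a lower number a stronger inhibitor), compound 1 gives 34000 nM. Within the data shown here, the only other measured member, compound 2 `O=C1C[C@@](C(=O)O)([C@@H](Cl)C(=O)O)O1`, carries a lactone core with a chlorine in place of the sulfur group; in this assay compound 2 gives 340000 nM, a weaker result that lies beyond the scatter from compound 1. Among the measured compounds shown here, no step between measured compounds that differ in one place is available, so the sulfur substituent is not yet calibrated.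

Compound 3 `O=C(O)C[C@@](O)(C(=O)O)[C@H](S)C(=O)O` keeps the open hydroxy core of compound 1 and differs only by hydrogen in place of methyl on a sulfur. With nothing measured on this change, the expected step from compound 1 to compound 3 is a 1.4-fold lower number from compound 1 to compound 3 (0.13 log units; within the scatter), which is taken as none beyond the scatter. Compound 3 is therefore estimated at 25000 nM, within a range of 8000 nM to 80000 nM.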

Compound 3, inhibition constant: 58000 nM
The estimate for compound 3 lay 2.3-fold (0.37 log units) below the measured number; the range from low to high includes it.
By their numbers in this assay, from the lowest: compounds 1 and 3 (each within the scatter of the next); then compound 2.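

Going from methylsulfanyl to sulfanyl on the saturated chain carbon gives the first calibrated step at this position: in this assay it reads a 1.7-fold higher number from compound 1 to compound 3 (0.23 log units; within the scatter) and leaves the two compounds indistinguishable. On the core of compound 1, the methyl on the sulfur can therefore be removed without a shift that can be separated from the scatter of repeated measurements. The data shown offer no independent measurement that would explain this result.

Still open, on these data alone, is whether a longer chain on the sulfur, such as ethyl or benzyl, would move the number in this assay beyond the scatter. Also open, as far as these compounds go, is whether an amine or a hydroxyl group in place of the sulfur group would do so on the same core.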